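The compounds below may be only part of what the source reports. "The series", "measured", "known", "first", "only" and "open" are said of these compounds alone.

Compound 1 `Cc1cn2c(-c3cn[nH]c3)cnc2c(Nc2cc(Cc3ncccn3)ns2)n1` stands second highest of three compounds in an ADME assay on the whole organism for pharmacokinetics, with Rattus norvegicus as the target, with a stated time of 6 h, at a dose of 10 mg/kg by the oral route (a higher number here means more compound in the circulation at the dose given, a lower number less compound in the circulation), where compound 1 gives 701 ng.h/mL. The other two differ from it only in the ring on a saturated chain carbon bound to an aromatic carbon: compound 2 `Cc1cn2c(-c3cn[nH]c3)cnc2c(Nc2cc(Cc3cnccn3)ns2)n1` gives 58.4 ng.h/mL, while compound 3 `Cc1cn2c(-c3cn[nH]c3)cnc2c(Nc2cc(Cc3ccccn3)ns2)n1` gives 6880 ng.h/mL. These shifts are all beyond the scatter: a 12-fold lower number from compound 1 to compound 2 (1.08 log units; beyond the scatter), a 9.8-fold higher number from compound 1 to compound 3 (0.99 log units; beyond the scatter) and a 120-fold higher number from compound 2 to compound 3 (2.07 log units; beyond the scatter). Compound 4 `COc1cccc(Cc2cc(Nc3nc(C)cn4c(-c5cn[nH]c5)cnc34)sn2)n1` carries 6-methoxypyridin-2-yl in place of pyrimidin-2-yl on a saturated chain carbon bound to an aromatic carbon. Going by the values given here, of the measured steps, a 9.8-fold higher number from compound 1 to compound 3 (0.99 log units; beyond the scatter) bears most closely on this change, compound 3 likewise carrying a pyridin-2-yl ring at that carbon; the methoxy group itself has no measured precedent here. A rise beyond the scatter is therefore expected, a 4.3-fold higher number from compound 1 to compound 4 (0.63 log units; beyond the scatter), though smaller than that seen for compound 3. Compound 4 is estimated at 3000 ng.h/mL, between 800 ng.h/mL and 12000 ng.h/mL.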

Compound 4, area under the concentration-time curve: 2300 ng.h/mL
The estimate for compound 4 lay 1.3-fold (0.12 log units) above the measured number; the measured number falls inside the stated range.
By their numbers in this assay, from the lowest: compound 2; then compound 1; then compound 4; then compound 3.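

Adding methoxy to the pyridin-2-yl ring gives the first reading of a substituent on this ring in this assay, and it lowers the number (a 3.0-fold lower number from compound 3 to compound 4 (0.48 log units; beyond the scatter)). The 6-methoxypyridin-2-yl ring still keeps the number above both the pyrimidin-2-yl ring (a 3.3-fold higher number from compound 1 to compound 4 (0.52 log units; beyond the scatter)) and the pyrazin-2-yl ring (a 39-fold higher number from compound 2 to compound 4 (1.60 log units; beyond the scatter)). No measurement at hand explains these shifts.

From the compounds shown here alone, whether methoxy lowers the number through its size or through some other feature remains open. So does whether an amine or a carboxylic acid in its place would lower the number as well.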